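The compounds below may be only part of what the source reports. "The series", "measured", "known", "first", "only" and "open" are said of these compounds alone.

Two compounds of the series have a number in a functional assay on A549 cells (Homo sapiens) for cytotoxicity, read by MTT assay, with a stated time of 72 h; on this read-out higher numbers stand for weaker inhibition and lower numbers for stronger inhibition. Compound 1 `CCC(=O)N1C/C(=C\c2cc(OC)c(OC)c(OC)c2)C(=O)/C(=C/c2cc(OC)c(OC)c(OC)c2)C1` gives 800 nM, the lowest of the two; compound 2 `COc1ccc(/C=C2\CNC/C(=C\c3ccc(OC)c(OC)c3)C2=O)cc1OC` gives 2900 nM, a higher number, beyond the scatter. Compound 3 `COc1cc(/C=C2\CN(C(=O)CCC(=O)O)C/C(=C\c3cc(OC)c(OC)c(OC)c3)C2=O)cc(OC)c1OC` is not yet measured; it differs from compound 1 by carboxy in place of hydrogen on a saturated chain carbon, two bonds along the chain from a carbonyl carbon. For the measured compounds named here, no measured pair shows a change of this kind, so there is nothing to anchor its size; a small step toward a higher number, within the scatter, is expected, a 1.5-fold higher number from compound 1 to compound 3 (0.18 log units; within the scatter). For compound 3 the estimate in this assay is 1200 nM, with a range from 400 nM to 4000 nM.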

Compound 3, half-maximal inhibitory concentration: 17900 nM
Compound 3: middle estimate off by 15-fold (1.17 log units), on the low side; the whole stated range lies below it.
By their numbers in this assay, from the lowest: compound 1; then compound 2; then compound 3.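

Propanoyl to (2-carboxyethyl)carbonyl is the first single-place step in the series, and in this assay it gives a 22-fold higher number from compound 1 to compound 3 (1.35 log units; beyond the scatter). This position is therefore not neutral: the number is sensitive to carboxy in place of hydrogen on this saturated chain carbon. Nothing measured here accounts for the size of the step.

Open: whether an amine, a methyl ester or a longer chain ending in a carboxylic acid at this place would shift the number to a similar extent.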